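Biphenyl ketone on a shared core: expecting compound 4

A few compounds are considered here, and "the series" means these few. Any claim that something is new, unique, unknown or untested is made for them only; others in the source may bear on it.

Measured so far:
compound 1 `COc1cc(C(=O)C2Sc3nnc(-c4cc(OC)c(OC)c(OC)c4)n3NC2c2ccco2)cc(OC)c1OC`: 52200 nM
compound 2 `COc1cc(-c2nnc3n2NC(c2ccco2)C(C(=O)c2ccc(Br)cc2)S3)cc(OC)c1OC`: 36400 nM
compound 3 `COc1cc(-c2nnc3n2NC(c2ccco2)C(C(=O)c2ccc(O)cc2)S3)cc(OC)c1OC`: 38300 nM

All three share one core and were tested in a functional assay on PC-3 cells (Homo sapiens) for cytotoxicity, read by MTT assay, with a stated time of 48 h; a lower number here means a stronger inhibitor, a higher number a weaker inhibitor. Compound 1 gives the largest of the three numbers, but this sets it apart from nothing: a 1.4-fold lower number from compound 1 to compound 2 (0.16 log units; within the scatter), and a 1.4-fold lower number from compound 1 to compound 3 (0.13 log units; within the scatter). The two others are just as close to each other, since a 1.1-fold higher number from compound 2 to compound 3 (0.02 log units; within the scatter).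

Compound 4 `COc1cc(-c2nnc3n2NC(c2ccco2)C(C(=O)c2ccc(-c4ccccc4)cc2)S3)cc(OC)c1OC` is a new member of the same series. It differs from compound 1 by 4-phenylphenyl in place of 3,4,5-trimethoxyphenyl on a carbonyl carbon. The two steps that bear on this change are those from compound 1 to compound 2 and from compound 1 to compound 3, in which the same group on the same carbonyl carbon was exchanged for another aromatic ring; both stayed within the scatter. A third aromatic replacement at that position is therefore expected to behave alike, giving a 1.2-fold lower number from compound 1 to compound 4 (0.09 log units; within the scatter) with no direction beyond the scatter. Compound 4 is estimated at 42000 nM, within the range 15000 nM to 110000 nM, in this assay.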

Compound 4, half-maximal inhibitory concentration: 45900 nM
Beside the measured number, compound 4's estimate is 1.1-fold (0.04 log units) below it, within the range that was stated.
By their numbers in this assay, from the lowest: compounds 2, 3, 4 and 1 (each within the scatter of the next).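

In this assay, replacing 3,4,5-trimethoxyphenyl on the carbonyl carbon with 4-phenylphenyl gives a 1.1-fold lower number from compound 1 to compound 4 (0.06 log units; within the scatter), even though the entering group has 2 six-membered aromatic rings and 0 hydrogen-bond acceptors where the leaving group has one such ring and 3 acceptors. Adding a whole phenyl ring to the 4-substituted ketones also leaves the number unmoved, with a 1.2-fold higher number from compound 3 to compound 4 (0.08 log units; within the scatter) and a 1.3-fold higher number from compound 2 to compound 4 (0.10 log units; within the scatter), so all four aryl groups at this position now sit within the scatter of one another. Nothing available here explains this flat response.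

All the groups shown on this carbonyl carbon are aromatic, so a simple alkyl chain there remains untested in these data. Also open, on these data alone, is whether a phenyl ring carrying an amine or a carboxylic acid would move the number beyond the scatter.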